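The source may report more compounds than this note shows. Statements on the series, on what has been measured and on what is new or still open speak of the compounds shown alone.

Of the compounds shown here, three share a common core and have been tested in a functional assay on Right cardiac atrium for agonist activity at histamine H2 receptor (Cavia porcellus), with a stated time of 30 min, in the presence of a further agent that is not named here; on this read-out higher numbers stand for an effect only at larger amounts of compound and lower numbers for an effect already at smaller amounts. Compound 2 `CCCCCNC(=O)/N=C(\N)NCCCc1sc(N)nc1C` gives 5.75 nM, the lowest number among the three; the gap to the others is beyond the usual scatter in both cases. Compound 1 `Cc1nc(N)sc1CCCN/C(N)=N/C(=O)NC(C)c1cccc(F)c1` gives 26.3 nM in this assay, and compound 3 `Cc1nc(N)sc1CCCN/C(N)=N/C(=S)N[C@H](C)c1ccccc1` gives 89.1 nM.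

The untested compound 4 `Cc1nc(N)sc1CCCN/C(N)=N/C(=O)N[C@H](C)c1ccccc1` differs from compound 2 in a single place: 1-phenylethyl in place of pentyl on an amide-type nitrogen. Among the measured compounds shown here, no directly comparable pair among the measured compounds describes this exact exchange, so the expectation rests on the neighbouring results. Compound 1, which also carries a 1-phenylethyl type group on the amide-type nitrogen, stands at 26.3 nM, well above compound 2.

For compound 4 the expected step is a 4.3-fold higher number from compound 2 to compound 4 (0.64 log units; beyond the scatter), upward and beyond the scatter. Compound 4 is therefore estimated at 25 nM in this assay, with a plausible range from 8 nM to 80 nM.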

Compound 4, half-maximal effective concentration: 7.59 nM
Compound 4: the middle estimate sits 3.3-fold (0.52 log units) above what was measured; the whole stated range lies above it.
By their numbers in this assay, from the lowest: compounds 2 and 4 (each within the scatter of the next); then compound 1; then compound 3.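

In this assay, 1-phenylethyl in place of pentyl on an amide-type nitrogen gives a 1.3-fold higher number from compound 2 to compound 4 (0.12 log units; within the scatter). Among the compounds shown here, on this read-out, the open pentyl chain and a group with a six-membered aromatic ring and a defined stereocentre therefore cannot be told apart at this position, which the earlier compounds could not show, as each differs from compound 2 in more than one place. Nothing available here explains this result.

The compounds shown leave open how the opposite stereocentre of 1-phenylethyl would read at this nitrogen. They also leave open whether a benzyl group, a cyclohexyl ring or a longer chain such as octyl would fit the same picture, or whether an amine at the end of the pentyl chain would shift the number.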